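A Straight Chain in Place of a Branched One

A few compounds are considered here, and "the series" means these few. Any claim that something is new, unique, unknown or untested is made for them only; others in the source may bear on it.

Compound 1 `CC(=O)OC[C@H]1O[C@@H](n2cc(-c3cc(-c4ccc(C(C)(C)C)cc4)no3)c(=O)[nH]c2=O)C[C@@H]1OC(C)=O`: 69.3%
Compound 2 `CC(=O)OC[C@H]1O[C@@H](n2cc(-c3cn(Cc4ccccc4)nn3)c(=O)[nH]c2=O)C[C@@H]1OC(C)=O`: 102%

Within the data shown here, in a functional assay on MDA-MB-231 cells (Homo sapiens) for cytotoxicity, read by sulforhodamine B assay, tested at 10 uM (a higher number here means more inhibition at the concentration tested (going by the name of the read-out), a lower number less inhibition), compound 1 gives 69.3%, the lowest of the two numbers measured so far. Compound 2 gives 102%, a number higher by a margin beyond the usual scatter of this kind of measurement. Compound 3 `CCCCc1ccc(-c2cc(-c3cn([C@H]4C[C@H](OC(C)=O)[C@@H](COC(C)=O)O4)c(=O)[nH]c3=O)on2)cc1` has the same atoms as compound 1, joined differently: butyl in place of tert-butyl on an aromatic carbon. The group that changes keeps its size, and the rest of the molecule stays as it is. Among the measured compounds shown here, no two measured compounds differ from each other in this way, so no measured step shows what such a swap does here. Compound 3 is therefore expected to give about 70%, with a likely range from 45% to 92%. The step of a number 0.7 percentage points higher from compound 1 to compound 3 (within the scatter) is expected to be none beyond the scatter, in either direction.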

Compound 3, a percentage reported as inhibition, at one concentration (the size of the read-out at that concentration, not a potency): 72.2%
Estimate against measurement, compound 3: 2.2 percentage points below; measured number inside the range.
By their numbers in this assay, from the lowest: compounds 1 and 3 (each within the scatter of the next); then compound 2.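

In this assay, among these compounds, putting butyl in place of tert-butyl on the aromatic carbon gives a number 2.9 percentage points higher from compound 1 to compound 3 (within the scatter) and is the first single change that can be read. At this position, para to a large group, the assay therefore does not tell the branched chain from the straight one, even though the carbon atoms are joined differently. No measurement at hand gives a reason for this result.

The compounds shown leave open what a longer chain such as hexyl, or an amine or a carboxylic acid, would do at this same position. They also leave open whether removing the chain altogether, with a plain hydrogen in its place, would give a step beyond the scatter.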